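A few compounds are considered here, and "the series" means these few. Any claim that something is new, unique, unknown or untested is made for them only; others in the source may bear on it.

In a functional assay on HL-60 cells (Homo sapiens) for inhibition, read by MTT assay, with a stated time of 72 h (a lower number here means a stronger inhibitor, a higher number a weaker inhibitor), compound 1 `Cc1ccc(N2CCN(C(=O)c3oc(C)nc3-c3ccccc3)CC2)cc1` gives > 1000 nM, which is a limit and not a number. Compound 2 `CCc1nc(-c2ccc(OC)cc2)c(C(=O)N2CCN(c3cccc(Cl)c3)CC2)o1` also gives a limit, > 1000 nM. Compound 1 therefore stands at the limit of > 1000 nM in this assay, at which 2 of the 2 values shown sit. Compound 3 `Cc1cc(C)cc(N2CCN(C(=O)c3oc(C)nc3-c3ccccc3)CC2)c1` carries 3,5-dimethylphenyl in place of 4-methylphenyl on an amine nitrogen in a ring. Going by the values given here, no measured step between two compounds is available as a guide, so no change beyond the scatter is expected in this assay, and the expected step is a number no higher from compound 1 to compound 3 (the limit leaves the size open). Compound 3 is estimated at 1000 nM, within an expected range of 300 nM to 3000 nM.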

Compound 3, half-maximal inhibitory concentration: 34.5 nM
Compound 3: the middle estimate sits 29-fold (1.46 log units) above what was measured; measured number outside the range, below it.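

In this assay, the group on the amine nitrogen of the six-membered ring proves able to move the result: 3,5-dimethylphenyl in place of 4-methylphenyl gives an at least 28-fold lower number from compound 1 to compound 3 (1.46 log units; beyond the scatter). From the compounds shown here alone, the value of compound 1 is a limit, so the full size of this step stays open. Compound 3 is the only compound shown with a number rather than a limit: the limit of > 1000 nM in this assay, at which 2 of the 3 values shown sit.

The compounds shown leave open whether a single methyl, as in 3-methylphenyl, would be enough at this position. They also leave open whether other groups, such as 3,5-dimethoxyphenyl, would keep the number of compound 3.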